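The source may hold more compounds than are shown below. What is called first, only, known or untested is meant among the compounds shown, and "the series" means these compounds.

Compound 1 `CCN(CC)CCNC(=O)c1ccc(C(CC)(CC)c2ccc(OCCC(O)(CC)CC)c(C)c2)n1CC`: 2.3 nM
Compound 2 `C#CC(C)OC(=O)c1ccc(C(CC)(CC)c2ccc(OCCC(O)(CC)CC)c(C)c2)n1CC`: 2650 nM

In an assay on cells for agonist activity at vitamin D3 receptor (Homo sapiens), with a stated time of 96 h (a lower number here means that less compound is needed, a higher number that more compound is needed for the effect), compound 1 gives the lower of the two numbers; compound 2 gives a far higher number, and the step of a 1200-fold higher number from compound 1 to compound 2 (3.06 log units; beyond the scatter) is large. Compound 3 `CCC(C)C(CO)NC(=O)c1ccc(C(CC)(CC)c2ccc(OCCC(O)(CC)CC)c(C)c2)n1CC` differs from compound 1 by 1-(hydroxymethyl)-2-methylbutyl in place of 2-(diethylamino)ethyl on an amide-type nitrogen, keeping the amide while dropping the amino chain. For the measured compounds named here, only the step from compound 1 to compound 2 bears on this, and it mixes two alterations, so its size is taken as an upper bound. A moderate loss is therefore expected, a 13-fold higher number from compound 1 to compound 3 (1.12 log units; beyond the scatter). For compound 3 the estimate is 30 nM, between 3 nM and 300 nM.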

Compound 3, half-maximal effective concentration: 450 nM
Estimate against measurement, compound 3: 15-fold (1.18 log units) below, and the stated range ends below it.
By their numbers in this assay, from the lowest: compound 1; then compound 3; then compound 2.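

In this assay, keeping the amide does not preserve the low number: 1-(hydroxymethyl)-2-methylbutyl in place of 2-(diethylamino)ethyl on the amide-type nitrogen gives a 200-fold higher number from compound 1 to compound 3 (2.29 log units; beyond the scatter). On the carbonyl carbon, (1-(hydroxymethyl)-2-methylbutyl)amino in place of (1-methylprop-2-yn-1-yl)oxy gives only a 5.9-fold lower number from compound 2 to compound 3 (0.77 log units; beyond the scatter), so a large part of the earlier loss appears with the amide still present. No evidence at hand bears on the reason for these steps. The compounds shown leave open whether the amine itself matters; a 2-(dimethylamino)ethyl group or a plain hexyl chain on this nitrogen would address that.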